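Moving the methyl on compound 3 to give compound 4

The source may hold more compounds than are shown below. What is called first, only, known or untested is meant among the compounds shown, and "the series" means these compounds.

Compound 1, `COc1cc2c(cc1OC)C(CC(=O)Nc1ccc(Cl)cc1)CC2`: 73.6%
Compound 2, `COc1cc2c(cc1OC)C(CC(=O)Nc1ccccc1C)CC2`: 30%
Compound 3, `COc1cc2c(cc1OC)C(CC(=O)Nc1cccc(C)c1)CC2`: 54.3%

All three were tested in a functional assay on the whole organism (strain Swiss Albino) for inhibition, with Mus musculus as the target, in the writhing test, with a stated time of 1 h, at a dose of 100 mg/kg by the oral route; on this read-out lower numbers stand for less inhibition and higher numbers for more inhibition at the one dose given (going by the name of the read-out). Compound 3 stands second highest of the three numbers. The step of a number 19.3 percentage points lower from compound 1 to compound 3 (beyond the scatter) is modest and beyond the scatter, and the step of a number 24.3 percentage points higher from compound 2 to compound 3 (beyond the scatter) is likewise modest and beyond the scatter; the largest gap among the three is a number 43.6 percentage points lower from compound 1 to compound 2 (beyond the scatter).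

Compound 4, `COc1cc2c(cc1OC)C(CC(=O)Nc1ccc(C)cc1)CC2`, has not yet been measured in this assay. Its difference from compound 3 is 4-methylphenyl in place of 3-methylphenyl on an amide-type nitrogen. Within the data shown here, the steps that bear on this change are those that move or swap the group on the amide-type nitrogen: a number 24.3 percentage points higher from compound 2 to compound 3 (beyond the scatter) and a number 19.3 percentage points lower from compound 1 to compound 3 (beyond the scatter). Among the measured compounds shown here, no measured step places a 4-methylphenyl on that nitrogen, so the direction rests only on compound 1, whose 4-chlorophenyl gives the highest value of the three, 73.6%. A modest rise, a number 7.7 percentage points higher from compound 3 to compound 4 (within the scatter), is therefore expected. Compound 4 is estimated at 62%, within a range from 44% to 80%.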

Compound 4, a percentage reported as inhibition, in the whole organism at one dose (the size of the read-out at that dose, not a potency): 41.4%
The estimate for compound 4 lay 20.6 percentage points above the measured number; the whole stated range lies above it.
By their numbers in this assay, from the lowest: compound 2; then compound 4; then compound 3; then compound 1.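

On the amide-type nitrogen, the place of the methyl on the phenyl ring now gives a full order in this assay: the change to 4-methylphenyl gives a number 12.9 percentage points lower from compound 3 to compound 4 (beyond the scatter) and, from the other side, a number 11.4 percentage points higher from compound 2 to compound 4 (beyond the scatter), so among the three methylphenyl compounds 3-methylphenyl is highest, 4-methylphenyl in the middle and 2-methylphenyl lowest. The high number of compound 1 does not carry over when its 4-chlorophenyl becomes 4-methylphenyl, since methyl in place of chloro on the aromatic carbon gives a number 32.2 percentage points lower from compound 1 to compound 4 (beyond the scatter). Nothing available gives a reason for this order.

The compounds shown leave open whether a 3-chlorophenyl or 2-chlorophenyl group would follow the order of the methyl series. They also leave open how a 4-methoxyphenyl or 4-fluorophenyl group on that nitrogen would compare with 4-chlorophenyl and 4-methylphenyl.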